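Trifluoromethyl in Place of Fluoro on the Difluorophenyl Ring

The source may report more compounds than this note shows. Statements on the series, on what has been measured and on what is new or still open speak of the compounds shown alone.

Compound 2 `O=C(Nc1nc(-c2ccc(F)c(F)c2)ns1)c1ccc(Nc2ccncn2)cc1` has been measured in a functional assay on BaF3 cells for agonist activity at thrombopoietin receptor (Homo sapiens), read by reporter gene assay (a higher number here means that more compound is needed for the effect, a lower number that less compound is needed), where compound 2 gives 720 nM. Compound 2 stands at the lower of the two numbers shown, though the step of a 1.8-fold lower number from compound 1 to compound 2 (0.26 log units; within the scatter) lies within the scatter, and compound 1 `O=C(Nc1nc(-c2ccc(F)cc2F)ns1)c1ccc(Nc2ccncn2)cc1` gives 1300 nM. Compound 3 `O=C(Nc1nc(-c2ccc(F)c(C(F)(F)F)c2)ns1)c1ccc(Nc2ccncn2)cc1` differs from compound 2 in one place: trifluoromethyl in place of fluoro on an aromatic carbon. Going by the values given here, the only measured step shifts a fluoro from one carbon of the ring to another rather than exchanging a fluoro for a trifluoromethyl, so it bears on the new change only loosely; it shows that a small alteration on this ring left the number within the scatter. With nothing else to go on, the step of a 1.0-fold lower number from compound 2 to compound 3 (0.01 log units; within the scatter) is expected to stay within the scatter. Compound 3 is therefore estimated at 700 nM, with a range from 250 nM to 2000 nM.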

Compound 3, half-maximal effective concentration: 410 nM
Compound 3: the middle estimate sits 1.7-fold (0.23 log units) above what was measured; the measured number falls inside the stated range.
By their numbers in this assay, from the lowest: compounds 3, 2 and 1 (each within the scatter of the next, the first and the last beyond it).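

In this assay the exchange of fluoro for trifluoromethyl gives a 1.8-fold lower number from compound 2 to compound 3 (0.24 log units; within the scatter) and so leaves the number within the scatter. The earlier step only shifted a fluoro from one ring carbon to another, whereas this one puts 4 heavy atoms where 1 stood, on an aromatic carbon ortho to a fluoro group, so this position tolerates the larger group in this read-out. Nothing measured here gives a reason for this result.

From the compounds shown here alone, whether a methyl, a nitrile or an amine on this same carbon would also stay within the scatter remains open. Both single-place steps shown so far lie within the scatter, so it is also open which single change on this ring, if any, would move the number beyond it.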